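This account rests on a few compounds, and the source may have more. Where it says the series, first, only, none or still open, it means among the compounds named here.

Working notes on the benzylamine series. Compound 1 `OC[C@H]1O[C@@H](n2cnc3c(NCc4ccccc4F)ncnc32)[C@H](O)[C@@H]1O` gives 3200 nM in a functional assay on HL-60 cells (Homo sapiens) for antiproliferative activity, with a stated time of 72 h; on this read-out lower numbers stand for stronger inhibition and higher numbers for weaker inhibition. Compound 2 `OC[C@H]1O[C@@H](n2cnc3c(NCc4ccccc4Cl)ncnc32)[C@H](O)[C@@H]1O` gives 1600 nM; the step of a 2.0-fold lower number from compound 1 to compound 2 (0.30 log units; within the scatter) is within the scatter, so compound 1 and compound 2 cannot be separated on this read-out. Compound 3 `OC[C@H]1O[C@@H](n2cnc3c(NCc4cccc(Br)c4)ncnc32)[C@H](O)[C@@H]1O` gives 8000 nM and stands apart from both, with a 2.5-fold higher number from compound 1 to compound 3 (0.40 log units; beyond the scatter) and a 5.0-fold higher number from compound 2 to compound 3 (0.70 log units; beyond the scatter) both beyond the scatter. Compound 4 `Cc1cccc(CNc2ncnc3c2ncn3[C@@H]2O[C@H](CO)[C@@H](O)[C@H]2O)c1` differs from compound 1 by 3-methylphenyl in place of 2-fluorophenyl on a saturated chain carbon bound to a nitrogen on an aromatic ring. The two steps that bear on this change, the ones leading to compound 3, both run toward weaker inhibition and are modest. A modest step toward weaker inhibition is therefore expected: a 2.0-fold higher number from compound 1 to compound 4 (0.31 log units; beyond the scatter). Compound 4 is estimated at 6500 nM, with a range from 2500 nM to 16000 nM.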

Compound 4, half-maximal inhibitory concentration: 6400 nM
Estimate against measurement, compound 4: 1.0-fold (0.01 log units) above; the range from low to high includes it.
By their numbers in this assay, from the lowest: compounds 2, 1, 4 and 3 (each within the scatter of the next, the first and the last beyond it).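

In this assay the 3-methylphenyl and 3-bromophenyl groups cannot be separated at this place, with methyl in place of bromo on an aromatic carbon giving only a step within the scatter (a 1.3-fold lower number from compound 3 to compound 4 (0.10 log units; within the scatter)). The step from 2-fluorophenyl also stays within the scatter (a 2.0-fold higher number from compound 1 to compound 4 (0.30 log units; within the scatter)), whereas the step from 2-chlorophenyl goes beyond it (a 4.0-fold higher number from compound 2 to compound 4 (0.60 log units; beyond the scatter)). No measurement at hand accounts for these steps. Still open, from the compounds shown here alone, is how 2-methylphenyl at this place compares with 2-chlorophenyl, and whether an aminophenyl or carboxyphenyl group there would stay within the range of these numbers.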